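The source may report more compounds than this note shows. Statements on the series, on what has been measured and on what is new or still open speak of the compounds shown alone.

In a functional assay on CEM-DNR-bulk cells (Homo sapiens), read by MTT assay, with a stated time of 72 h (a lower number here means a stronger inhibitor, a higher number a weaker inhibitor), three compounds sharing one core have been measured so far. Compound 1 `Nc1nc(N)c2c(-c3ccco3)cn([C@@H]3O[C@H](CO)[C@@H](O)[C@H]3O)c2n1`, which carries furan-2-yl, gives > 20000 nM, a limit and not a number. Compound 2 `Nc1nc(N)c2c(-c3cccs3)cn([C@@H]3O[C@H](CO)[C@@H](O)[C@H]3O)c2n1`, which carries thiophen-2-yl instead, gives > 20000 nM, also a limit. Compound 3 `Cc1nc(N)c2c(-c3ccco3)cn([C@@H]3O[C@H](CO)[C@@H](O)[C@H]3O)c2n1`, with methyl in place of amino on an aromatic carbon, gives > 20000 nM, again a limit. Compound 3 thus has no exact number, and the whole set stands at the limit of > 20000 nM in this assay, at which 3 of the 3 values shown sit.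

Compound 4 `Cc1nc(N)c2c(-c3cccs3)cn([C@@H]3O[C@H](CO)[C@@H](O)[C@H]3O)c2n1` differs from compound 3 by one change, thiophen-2-yl in place of furan-2-yl on an aromatic carbon. The same swap has been measured once, as a step that the two limits leave unreadable from compound 1 to compound 2. The other measured change is a step that the two limits leave unreadable from compound 1 to compound 3. Neither has a readable size, so the expectation is no change beyond the scatter, and the estimated step is a number no higher from compound 3 to compound 4 (the limit leaves the size open). For compound 4 the expected value is 20000 nM, with an estimated range of 8000 nM to 40000 nM.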

Compound 4, half-maximal inhibitory concentration: > 20000 nM
Compound 4 was reported as a limit (the forecaster's own chance of this, stated with the estimate: 85%); the middle value sits exactly at the limit.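

Compound 4 gives only a limit, as do compound 2 and compound 3, so neither new step to compound 4 can be read: the limit of > 20000 nM in this assay, at which 4 of the 4 values shown sit.

As far as these compounds go, whether thiophen-2-yl in place of furan-2-yl, or methyl in place of amino, changes inhibition at all stays open.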